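Isopropyl to propyl on the aryl oxygen: outlook for compound 4

The source may report more compounds than this note shows. Statements on the series, on what has been measured and on what is new or still open speak of the compounds shown alone.

Three compounds of the series carry numbers in a toxicity assay on Huh-7.5 cells (Homo sapiens) for inhibition, read by MTT assay, with a stated time of 96 h; on this read-out higher numbers stand for lower toxicity in this test and lower numbers for higher toxicity in this test. Compound 3 `CCC(=O)Nc1cc(C(=O)Nc2ccc(OC)cc2)ccc1OC(C)C` gives 113000 nM, the highest of the three numbers. Within the data shown here, compound 1 `CCC(=O)Nc1cc(C(=O)Nc2ccc(N(C)C)cc2)ccc1OC(C)C` gives 80600 nM, and the step of a 1.4-fold higher number from compound 1 to compound 3 (0.15 log units; within the scatter) is the only one-place change with numbers on both sides. Compound 2 `CN1CCN(Cc2ccc(NC(=O)c3ccc(OCCCCl)c(S(N)(=O)=O)c3)cc2C(F)(F)F)CC1` differs from the others in more than one place and gives 5470 nM, the number furthest from compound 3 and beyond the scatter.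

Compound 4 `CCCOc1ccc(C(=O)Nc2ccc(OC)cc2)cc1NC(=O)CC` is not yet measured. Relative to compound 3 the change is propyl in place of isopropyl on an oxygen on an aromatic ring. Among the measured compounds shown here, no measured step covers this change: the single step available, a 1.4-fold higher number from compound 1 to compound 3 (0.15 log units; within the scatter), concerns a different pair of groups and stayed within the scatter. Nothing shown points in either direction for a propyl in place of an isopropyl, so no step beyond the scatter is expected. For compound 4 the expected step is a 1.0-fold lower number from compound 3 to compound 4 (0.01 log units; within the scatter). Compound 4 is accordingly estimated at 110000 nM, within a range from 55000 nM to 220000 nM.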

Compound 4, half-maximal cytotoxic concentration: 106000 nM
Beside the measured number, compound 4's estimate is 1.0-fold (0.02 log units) above it; the range from low to high includes it.
By their numbers in this assay, from the lowest: compound 2; then compounds 1, 4 and 3 (each within the scatter of the next).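

Among these compounds, at the aryl oxygen, the step of a 1.1-fold lower number from compound 3 to compound 4 (0.03 log units; within the scatter) in this assay is the first reading at this position, and it stays within the scatter. Rearranging the same atoms from isopropyl to propyl therefore does not separate compound 3 from compound 4 in this test. With the step from methoxy to dimethylamino read in the opposite direction, this gives two one-place changes in the series, neither beyond the scatter. No supporting measurement on either group accompanies this result, so its origin remains unaddressed.

Going by these compounds, whether a longer chain such as butyl, a benzyl group or a chain ending in an amine on this oxygen would shift the number remains open. Also open, on these data alone, is whether propyl in place of isopropyl behaves the same way with the dimethylamino group of compound 1 in place of methoxy.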